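The source may report more compounds than this note shows. Statements on the series, on what has been measured and on what is new or still open speak of the compounds shown alone.

Compound 1, `COCOc1cc(/C=C/C(=O)OCC(=O)Nc2ccc(Cl)cc2)ccc1OCc1ccccc1`: in a functional assay on PC-3 cells (Homo sapiens) for cytotoxicity, read by MTT assay, with a stated time of 72 h (on this read-out lower numbers stand for stronger inhibition and higher numbers for weaker inhibition), compound 1 gives > 200000 nM, which is a limit of the assay and not a number.
Compound 2, `O=C(COC(=O)/C=C/c1ccc(O)c(O)c1)NN1CCOCC1`: in this assay compound 2 gives > 200000 nM, likewise a limit.
Compound 3, `COc1ccc(NC(=O)COC(=O)/C=C/c2cc(OC)c(OCc3ccccc3)c(OC)c2)cc1`: in this assay compound 3 gives > 200000 nM, again a limit.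

Compound 1 thus stands nowhere inside the measurable range: its value is a limit, and all three values shown sit there, as the limit of > 200000 nM in this assay, at which 3 of the 3 values shown sit, records. No two of these compounds differ in a single place, so no measured step exists. Compound 4, `COCOc1cc(/C=C/C(=O)OCC(=O)Nc2nccs2)ccc1OCc1ccccc1`, arises from compound 1 by 1,3-thiazol-2-yl in place of 4-chlorophenyl on an amide-type nitrogen. With every measured compound at the limit, the expected step is a number no higher from compound 1 to compound 4 (the limit leaves the size open), nothing beyond the scatter. Compound 4 is therefore estimated at 200000 nM, within 60000 nM to 500000 nM, most likely reported once more as a limit.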

Compound 4, half-maximal inhibitory concentration: > 200000 nM
Compound 4: only a limit was reported; the forecaster's own chance of this, stated with the estimate: 85%; the middle value sits exactly at the limit.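

In this assay, for the compounds shown here, compound 4 gives > 200000 nM, a limit and not a number, so no step from compound 1 to compound 4 can be read. The compounds shown leave open what 1,3-thiazol-2-yl in place of 4-chlorophenyl changes, and where any of them would fall within the measurable range: the limit of > 200000 nM in this assay, at which 4 of the 4 values shown sit.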